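Swapping an Oxadiazole for Methoxy on a Benzamide Series

This account rests on a few compounds, and the source may have more. Where it says the series, first, only, none or still open, it means among the compounds named here.

Measured so far:
- compound 1 `COc1cccc(-c2ccc(C(=O)N(Cc3cccc(OCCCCCC(=O)O)c3)C(C)C)cc2)c1`: > 20900 nM
- compound 2 `CCOC(=O)CCCCCOc1cccc(CN(C(=O)c2ccc(-c3cccc(-c4nnc(C)o4)c3)cc2)C(C)C)c1`: > 26000 nM

Compound 1 has only a limit in an ADME assay on Raji cells (Homo sapiens) for cytotoxicity, read by CellTiter-Glo and resazurin assay, with a stated time of 72 h (a higher number here means that more compound is needed for the effect, a lower number that less compound is needed), given as > 20900 nM. Compound 2 likewise reaches only a limit in this assay, namely > 26000 nM. Where compound 2 stands is therefore not a number but an upper edge of what was tested, and the other value shown sits at a limit as well; no measured step between these two compounds is given, so nothing beyond that can be read from them.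

Compound 3 `CCOC(=O)CCCCCOc1cccc(CN(C(=O)c2ccc(-c3cccc(OC)c3)cc2)C(C)C)c1` differs from compound 2 in one place: methoxy in place of 5-methyl-1,3,4-oxadiazol-2-yl on an aromatic carbon. Both compounds keep the same ester-bearing side chain and the same shared core.

Since compound 2 gives > 26000 nM and, carrying the same methoxyphenyl group as compound 3, compound 1 gives > 20900 nM, no change beyond the scatter is expected in this assay. The step from compound 2 to compound 3 is expected to be a step that the limit leaves unreadable from compound 2 to compound 3. Compound 3 is estimated at 30000 nM, within 10000 nM to 100000 nM, most likely again as a limit.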

Compound 3, half-maximal effective concentration: > 21000 nM
Compound 3 ended at the assay's limit; the forecaster's own chance of this, stated with the estimate: 85%; the middle value does not contradict the limit.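

In this assay compound 3 gives > 21000 nM, which is a limit of the assay and not a number. Compound 1 and compound 2 also stand at limits, so neither step to compound 3 can be read. The compounds shown leave open whether either change alters the concentration needed for the effect.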